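Chain Length in a Thiourea Series Against Glioma Cells

The compounds below may be only part of what the source reports. "The series", "measured", "known", "first", "only" and "open" are said of these compounds alone.

compound 1, `CCCCCCCCCCCCCCCCCC1=C(C(=O)OC)C(c2cccc(O)c2)NC(=O)N1`: 21800 nM
compound 2, `CCCCCCCC/C=C\CCCCCCCC1=C(C(=O)OC)C(c2cccc(O)c2)NC(=O)N1`: 166000 nM
compound 3, `CCCCCCCCCCCCCCCC1=C(C(=O)OC)C(c2cccc(O)c2)NC(=S)N1`: 5110 nM

In a functional assay on C6 cells (Rattus norvegicus) for cytotoxicity, read by MTT assay, with a stated time of 48 h (on this read-out higher numbers stand for weaker inhibition and lower numbers for stronger inhibition), compound 3 gives the lowest of the three numbers, with compound 1 next and compound 2 furthest away. Compound 4, `CCCCCCCCCCCCCCCCCC1=C(C(=O)OC)C(c2cccc(O)c2)NC(=S)N1`, differs from compound 3 by ethyl in place of hydrogen on a saturated chain carbon, ten or more bonds along the chain from a double-bonded ring carbon. Going by the values given here, no measured step matches this change: the only step in hand, a 7.6-fold higher number from compound 1 to compound 2 (0.88 log units; beyond the scatter), concerns a double bond in the chain rather than its length, and compound 1 and compound 3 differ in both chain length and the thione, so their two values alone cannot separate the two effects. A lengthening of a long saturated chain is therefore expected to give at most a small step in this assay, likely within the scatter. Compound 4 is estimated at 6000 nM (range 2000 nM to 18000 nM), meaning an expected step of a 1.2-fold higher number from compound 3 to compound 4 (0.07 log units; within the scatter).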

Compound 4, half-maximal inhibitory concentration: 6850 nM
Compound 4: middle estimate off by 1.1-fold (0.06 log units), on the low side, within the range that was stated.
By their numbers in this assay, from the lowest: compounds 3 and 4 (each within the scatter of the next); then compound 1; then compound 2.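

In this assay, ethyl in place of hydrogen on this saturated chain carbon gives a 1.3-fold higher number from compound 3 to compound 4 (0.13 log units; within the scatter) and so changes little between these two chain lengths. The change also pairs compound 4 with compound 1, which has the same chain and a carbonyl in place of the thione: compound 1 gives 21800 nM while compound 4 gives 6850 nM in this comparison. Nothing available explains either result. On these data alone, whether a longer chain would behave the same remains open, as does the effect of an amine or a carboxylic acid on the chain.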